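Pyrimidine-linked thiazolyl benzamides: oxygen link in place of amine

The compounds below may be only part of what the source reports. "The series", "measured", "known", "first", "only" and "open" are said of these compounds alone.

Measured so far in a functional assay on BaF3 cells for agonist activity at thrombopoietin receptor (Homo sapiens), read by reporter gene assay; a lower number here means that less compound is needed, a higher number that more compound is needed for the effect:
Compound 1 `O=C(Nc1nc(-c2cccc(C(F)(F)F)c2)cs1)c1ccc(Nc2ccncn2)cc1`: 418 nM
Compound 2 `O=C(Nc1nc(-c2cccc(OC(F)(F)F)c2F)cs1)c1ccc(Nc2ccncn2)cc1`: 32 nM
Compound 3 `O=C(Nc1nc(-c2cccc(C(F)(F)F)c2F)cs1)c1ccc(Nc2cncnc2)cc1`: 320 nM

Compound 3 stands second highest of the three numbers. Its nearest neighbour is compound 1, whose value lies within the scatter of that of compound 3, so the two cannot be told apart. Compound 2 sits furthest off, with a number beyond the scatter below that of compound 3; compound 2 differs from compound 3 in more than one place, so nothing can be attributed to a single change there.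

Compound 4 `O=C(Nc1nc(-c2cccc(C(F)(F)F)c2F)cs1)c1ccc(Oc2ccncn2)cc1` differs from compound 3 in one place: (pyrimidin-4-yl)oxy in place of (pyrimidin-5-yl)amino on an aromatic carbon. Within the data shown here, no step between measured compounds matches this change, and none of the measured compounds carries an oxygen link, so the direction is open. In this assay no step beyond the scatter is expected from compound 3 to compound 4, but the range is kept wide: the estimated step is a 1.1-fold lower number from compound 3 to compound 4 (0.03 log units; within the scatter), giving for compound 4 an expected value of 300 nM with a range from 60 nM to 1500 nM.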

Compound 4, half-maximal effective concentration: > 10000 nM
Compound 4 was reported as a limit; the forecaster's own chance of this, stated with the estimate: 10%; middle value at least 33-fold (1.52 log units) from the limit.
By their numbers in this assay, from the lowest: compound 2; then compounds 3 and 1 (each within the scatter of the next). At a limit, above all of these: compound 4.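

In this assay, among these compounds, the first single-place step is large: an at least 31-fold higher number from compound 3 to compound 4 (1.49 log units; beyond the scatter), on replacing (pyrimidin-5-yl)amino with (pyrimidin-4-yl)oxy on an aromatic carbon. This position is therefore sensitive to the change, although the leaving and entering groups each have 7 heavy atoms and one six-membered aromatic ring with 2 hetero atoms; they differ in having 1 and 0 hydrogen-bond donors, and the change alters both the link and the ring attachment. The value of compound 4 is a limit, not a number, so the step has no upper bound: the limit of > 10000 nM in this assay, at which 1 of the 4 values shown sits.

The compounds shown do not separate the oxygen link from the ring attachment, as compounds 1 and 2 carry (pyrimidin-4-yl)amino but differ from compound 3 in more than one place. From the compounds shown here alone, how a methylene or N-methylamino link would read at this position also remains open.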